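From Cyclopropyl to 2,4-Difluorophenyl on an Aromatic Nitrogen

The compounds below may be only part of what the source reports. "The series", "measured", "known", "first", "only" and "open" are said of these compounds alone.

In a functional assay on V79 cells (Cricetulus griseus) for cytotoxicity, read by colony formation (on this read-out lower numbers stand for stronger inhibition and higher numbers for weaker inhibition), compound 1 `COc1c(N2CCCC2)c(F)cc2c(=O)c(C(=O)O)cn(C3CC3)c12` gives 150 ug/mL as its reading. Compound 2 `COc1c(N2CCC(N)C2)c(F)cc2c(=O)c(C(=O)O)cn(C3CC3)c12` gives 45 ug/mL; 44 ug/mL; 45 ug/mL (3 entries) over its repeated entries. Compound 3 `COc1c(N2CCC(C)(N)C2)c(F)cc2c(=O)c(C(=O)O)cn(C3CC3)c12` gives 38 ug/mL as the lower of the two single numbers, and this lies within the scatter of compound 2. Compound 4 `COc1c(N2CCC(C)(N)C2)c(F)cc2c(=O)c(C(=O)O)cn(-c3ccc(F)cc3F)c12` keeps the 3-amino-3-methylpyrrolidin-1-yl group of compound 3 and differs from it by 2,4-difluorophenyl in place of cyclopropyl on an aromatic nitrogen in one change: 2,4-difluorophenyl in place of cyclopropyl on an aromatic nitrogen. Going by the values given here, no measured step touches that nitrogen. Among the compounds with values here, the only step available is a 3.9-fold lower number from compound 1 to compound 3 (0.60 log units; beyond the scatter) for 3-amino-3-methylpyrrolidin-1-yl in place of pyrrolidin-1-yl on an aromatic carbon. It is modest and sits elsewhere on the core, so it serves only as a rough gauge of size. A smaller shift in this assay is therefore expected, leaning towards a higher number, with its direction uncertain. The expected step is a 1.6-fold higher number from compound 3 to compound 4 (0.20 log units; within the scatter) in this estimate. For compound 4 the estimated value is 60 ug/mL with an expected range of 20 ug/mL to 180 ug/mL here.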

Compound 4, half-maximal inhibitory concentration: 250 ug/mL
Compound 4: the middle estimate sits 4.2-fold (0.62 log units) below what was measured; measured number outside the range, above it.
By their numbers in this assay, from the lowest: compound 3; then compounds 1 and 4 (each within the scatter of the next).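

Going by these compounds alone, the change from cyclopropyl to 2,4-difluorophenyl on the aromatic nitrogen gives a 6.6-fold higher number from compound 3 to compound 4 (0.82 log units; beyond the scatter) in this assay, so this position, which the earlier compounds left untouched, does bear on the reading, and here the larger group goes with weaker inhibition. The step is graded modest, as is a 3.9-fold lower number from compound 1 to compound 3 (0.60 log units; beyond the scatter), but it runs the opposite way, so changes at the two places need not push the reading in the same direction. Repeated readings in this assay sit close together for the one compound with several entries: the several entries of compound 2 in this assay, 45 ug/mL; 44 ug/mL; 45 ug/mL (3 entries)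

On these data alone, whether a plain phenyl or an ethyl group on this nitrogen would read nearer compound 3 or compound 4 stays open. Also open, as far as these compounds go, is whether the same change would shift the reading with the 3-aminopyrrolidin-1-yl group of compound 2 in place.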